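What losing one side chain may do

The source may hold more compounds than are shown below. What is called first, only, known or untested is meant among the compounds shown, and "the series" means these compounds.

In an ADME assay on NIH3T3 cells (Mus musculus) for cytotoxicity, read by neutral red uptake, with a stated time of 48 h (on this read-out higher numbers stand for lower toxicity in this test and lower numbers for higher toxicity in this test), compound 1 (`CCCCCCCC/C=C\c1c(C)c(/C=C\CCCCCCCC)c2[n+](c1C)CCC2`) gives 22.7 uM and compound 2 (`CCCCCCCC/C=C/c1c(C)c(/C=C/CCCCCCCC)c2[n+](c1C)CCC2`) gives 2.5 uM and so stands lower of the two. Among the compounds with values here, the one measured step is a 9.1-fold lower number from compound 1 to compound 2 (0.96 log units; beyond the scatter) and it goes with the fact that compounds 1 and 2 differ only in the configuration as drawn alone. Compound 3 (`CCCCCCCC/C=C/c1c(C)cc(C)[n+]2c1CCC2`) departs from compound 2 by a hydrogen atom in place of a group of 10 heavy atoms (10 carbon; no ring), on an aromatic carbon on an aromatic carbon, two atoms from the ring nitrogen and ortho to two methyl groups. Within the data shown here, no measured step removes a group, so the configuration step bears on this change only loosely: it shows that the number can move beyond the scatter when only these chains differ. A higher number is expected, with little certainty. The expected shift is a 6.0-fold higher number from compound 2 to compound 3 (0.78 log units; beyond the scatter) and is similar in size to the configuration step. The estimate for compound 3 is 15 uM within a range from 4 uM to 60 uM on the same read-out.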

Compound 3, half-maximal toxic concentration: 1.9 uM
Compound 3: the middle estimate sits 7.9-fold (0.90 log units) above what was measured; measured number outside the range, below it.
By their numbers in this assay, from the lowest: compounds 3 and 2 (each within the scatter of the next); then compound 1.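

In this assay, putting a hydrogen atom in place of the group of 10 heavy atoms, on the aromatic carbon two atoms from the ring nitrogen, gives a 1.3-fold lower number from compound 2 to compound 3 (0.12 log units; within the scatter). The number therefore holds within the scatter at this position, so compound 2 does not need this chain to reach the number it gives in this test, and the rise in the number seen with a change in these chains does not appear with this removal. Nothing among the measured facts accounts for why the number holds when this chain leaves.

The compounds shown leave open whether a shorter chain, a longer chain or an amine at this position would also leave the number in place. They also leave open whether the same removal from compound 1, with its double bonds drawn Z, would do the same, and what losing the other chain would do.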